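This account rests on a few compounds, and the source may have more. Where it says the series, first, only, none or still open, it means among the compounds named here.

Measured so far:
- compound 1, `CC1(C)SC(c2ccccc2N)=NN1C(=O)c1ccccc1`: 39.8%
- compound 2, `CC1(C)SC(c2cc(Cl)ccc2N)=NN1C(=O)c1ccccc1`: 20.8%

In an assay on isolated protein for inhibition of Nitric oxide synthase, inducible (Homo sapiens), read by scintillation counting, with a stated time of 30 min, tested at 50 uM (a lower number here means less inhibition, a higher number more inhibition at the concentration tested (going by the name of the read-out)), compound 1 stands highest of the two numbers shown; its nearest neighbour is compound 2, and the only measured step is a number 19 percentage points lower from compound 1 to compound 2 (beyond the scatter), a chloro in place of hydrogen on an aromatic carbon. Compound 3, `CC1(C)SC(c2ccccc2N)=NN1C(=O)C1CCC1`, differs from compound 1 as follows: cyclobutyl in place of phenyl on a carbonyl carbon. Among the measured compounds shown here, no measured step touches the group on the carbonyl carbon, so nothing bears directly on this change. The expectation for compound 3 is therefore a step of a number 4.8 percentage points lower from compound 1 to compound 3 (within the scatter), within the scatter, with a wide range. Compound 3 is estimated at 35%, between 12% and 58%.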

Compound 3, a percentage reported as inhibition, at one concentration (the size of the read-out at that concentration, not a potency): 46.9%
Compound 3: middle estimate off by 11.9 percentage points, on the low side; low and high end bracket the measured number.
By their numbers in this assay, from the lowest: compound 2; then compounds 1 and 3 (each within the scatter of the next).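

In this assay, among the compounds shown here, the first reading at this position gives a number 7.1 percentage points higher from compound 1 to compound 3 (within the scatter) for cyclobutyl in place of phenyl on a carbonyl carbon. A non-aromatic ring with fewer carbons therefore holds the read-out at the level of compound 1, so the phenyl is not needed for this level of inhibition at the concentration tested. Nothing available explains this result.

Still open, from the compounds shown here alone, is whether an amine or a longer carbon chain on the carbonyl carbon would hold this level. Also open, going by these compounds, is whether the loss seen with chloro on the aromatic carbon carries over to compound 3.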